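The compounds below may be only part of what the source reports. "The series", "measured", "known", "first", "only" and "open" are said of these compounds alone.

In an in vitro functional assay on 1321-N1 cells for agonist activity at P2Y purinoceptor 2 (Homo sapiens), read by scintillation proximity assay and inositol phosphate accumulation (on this read-out higher numbers stand for an effect only at larger amounts of compound and lower numbers for an effect already at smaller amounts), compound 3 `Nc1nc(=O)ccn1[C@@H]1O[C@H](COP(=O)(O)O)[C@@H](O)[C@H]1O` sits at a limit of the assay, giving > 100000 nM. Compound 2 `CNc1nc(=O)ccn1[C@@H]1O[C@H](COP(=O)(O)O)[C@@H](O)[C@H]1O` likewise gives only a limit in this assay, > 100000 nM. Two of the three values shown therefore sit at the limit of > 100000 nM in this assay, at which 2 of the 3 values shown sit. Compound 1 `CCSc1nc(=O)ccn1[C@@H]1O[C@H](COP(=O)(O)O)[C@@H](O)[C@H]1O` gives 1500 nM in this assay, so the step of an at least 66-fold higher number from compound 1 to compound 3 (1.82 log units; beyond the scatter) and the step of an at least 66-fold higher number from compound 1 to compound 2 (1.82 log units; beyond the scatter) both run the same way, while the step that the two limits leave unreadable from compound 2 to compound 3 cannot be read from the two limits. Compound 4 `O=c1ccn([C@@H]2O[C@H](COP(=O)(O)O)[C@@H](O)[C@H]2O)c(SCCc2ccccc2)n1` has not yet been measured; it differs from compound 3 by phenethylsulfanyl in place of amino on an aromatic carbon. This reverses the direction of the measured steps: where ethylsulfanyl gave way to amino or methylamino, the number in this assay rose beyond the scatter, and here amino gives way to a sulfanyl group again, now phenethylsulfanyl. A large step downward is therefore expected in this assay, an at least 100-fold lower number from compound 3 to compound 4 (2.00 log units; beyond the scatter). That expectation rests on compound 1, which with ethylsulfanyl gave 1500 nM. Whether the longer phenethyl chain changes the outcome relative to ethyl cannot be read from the compounds shown. Compound 4 is estimated at 1000 nM, expected to fall between 150 nM and 8000 nM.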

Compound 4, half-maximal effective concentration: 1300 nM
Compound 4: middle estimate off by 1.3-fold (0.11 log units), on the low side, and the stated range covers the measured number.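

On the aromatic carbon between two ring nitrogen atoms, a second sulfanyl group now stands clearly apart from the nitrogen-linked groups in this assay, with an at least 76-fold lower number from compound 3 to compound 4 (1.88 log units; beyond the scatter) and an at least 76-fold lower number from compound 2 to compound 4 (1.88 log units; beyond the scatter). The size of both steps is bounded by assay limits rather than fixed by two numbers: the limit of > 100000 nM in this assay, at which 2 of the 4 values shown sit.

Among the compounds shown here, what the earlier compounds could not show is how the sulfanyl chain responds to added bulk, and adding a phenyl group to the ethyl chain gives a 1.2-fold lower number from compound 1 to compound 4 (0.06 log units; within the scatter), which leaves the ethylsulfanyl and phenethylsulfanyl compounds indistinguishable in this read-out.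

The compounds shown do not separate the part played by the sulfur from that of the attached carbon chain, and an ethoxy or phenethoxy group on the same carbon would be needed to address that. Also open, as far as these compounds go, is whether a shorter methylsulfanyl group, a longer phenylpropylsulfanyl chain, or a chlorine or methoxy group on the phenyl ring would move the number beyond the scatter.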